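This account rests on a few compounds, and the source may have more. Where it says the series, first, only, none or still open, it means among the compounds named here.

Measured so far:
- compound 1 `C[C@@H]1CN(c2ncc(OCc3ccc(S(C)(=O)=O)cc3)cn2)CCN1C(=O)OC(C)(C)C`: 16%
- compound 2 `C[C@H]1CN(c2ncc(OCc3ccc(S(C)(=O)=O)cc3)cn2)CCN1C(=O)OC(C)(C)C`: 45%
- compound 3 `C[C@@H]1CN(C(=O)OC(C)(C)C)C[C@H](C)N1c1ncc(OCc2ccc(S(C)(=O)=O)cc2)cn1`: 95%

The three compounds share one core and were all tested in a functional assay on isolated protein with Glucose-dependent insulinotropic receptor (Mus musculus) as the target, read by HTRF and cAMP accumulation, with a stated time of 45 min; a lower number here means a smaller maximal response, a higher number a larger maximal response. Compound 1 gives 16%, the lowest of the three numbers. Compound 2 gives 45%, and compound 3 gives 95%, the furthest from compound 1.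

Going by the values given here, only one step between measured compounds differs in a single place, the step from compound 1 to compound 2: a number 29 percentage points higher from compound 1 to compound 2 (beyond the scatter). This step rests on (the fact that compounds 1 and 2 differ only in the configuration as drawn), so it says how much a change of configuration alone can move the maximal response in this assay.

Compound 4 `C[C@@H]1CN(c2ncc(OCc3ccc(S(C)(=O)=O)cc3)cn2)[C@@H](C)CN1C(=O)OC(C)(C)C` is the next compound to be tested. It differs from compound 1 by methyl in place of hydrogen on a saturated ring carbon. Among the compounds with values here, no measured step of this kind, methyl in place of hydrogen on a saturated ring carbon, is available, so the expectation leans on the spread of the numbers seen so far: a single change of configuration moved the response beyond the scatter, and compound 3, which carries two methyl groups on its ring, gives 95%. On that basis compound 4 is expected at 50%, with a range from 20% to 85%, which means an estimated a number 34 percentage points higher from compound 1 to compound 4 (beyond the scatter).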

Compound 4, intrinsic activity: the largest response reached, in percent of the reference agonist's: 3%
Beside the measured number, compound 4's estimate is 47 percentage points above it, outside the stated range (below it).
By their numbers in this assay, from the lowest: compound 4; then compound 1; then compound 2; then compound 3.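

In this assay the added methyl gives a number 13 percentage points lower from compound 1 to compound 4 (beyond the scatter), so this saturated ring carbon, next to the ring nitrogen, responds to the gain of a single methyl. Going by these compounds alone, the change lowers the maximal response of a compound that already stood low, and it is the first measured step in which an atom is added to the ring rather than a configuration changed. The new methyl is drawn in one configuration only, and that limits the reading, since configuration alone gave a number 29 percentage points higher from compound 1 to compound 2 (beyond the scatter), a step that rests on one fact: the fact that compounds 1 and 2 differ only in the configuration as drawn

The compounds shown leave open how the opposite configuration at this carbon would read, and whether an ethyl or a hydroxymethyl group here would lower the response as the methyl does. They also leave open how the same methyl would read on the core of compound 2, whose existing ring methyl is drawn the other way.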